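Swapping dimethylamino for hydroxy on the aryl ring

The compounds below may be only part of what the source reports. "The series", "measured", "known", "first", "only" and "open" are said of these compounds alone.

Of the compounds shown here, three sharing one core have been measured. Compound 1 `CCCCCCCCCCCCCCCCCCNC(=O)[C@@H]1CSC(c2cccc(O)c2)N1` gives 6700 nM in a functional assay on PC-3 cells (Homo sapiens) for antiproliferative activity, read by sulforhodamine B assay; on this read-out higher numbers stand for weaker inhibition and lower numbers for stronger inhibition. Compound 2 `CCCCCCCCCCCCCCCCCCNC(=O)[C@@H]1CSC(c2ccc(OC)cc2)N1` gives 19000 nM in this assay, and compound 3 `CCCCCCCCCCCCCCCCCCNC(=O)[C@@H]1CSC(c2ccc(N(C)C)cc2)N1` gives 6000 nM. Compound 3 thus holds the lowest of the three numbers, though its distance to compound 1 is within the scatter; the remaining step, a 3.2-fold lower number from compound 2 to compound 3 (0.50 log units; beyond the scatter), lies beyond it.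

Compound 4 `CCCCCCCCCCCCCCCCCCNC(=O)[C@@H]1CSC(c2ccc(O)cc2)N1` has not yet been measured. It differs from compound 3 by hydroxy in place of dimethylamino on an aromatic carbon. Two earlier steps bear on this. The step of a 3.2-fold lower number from compound 2 to compound 3 (0.50 log units; beyond the scatter) went the other way, from methoxy to dimethylamino, and the step of a 2.8-fold higher number from compound 1 to compound 2 (0.45 log units; beyond the scatter) compared a hydroxy group at one position with a methoxy at another. Compound 1, carrying a hydroxy group elsewhere on the ring, sits near compound 3. A step of a 1.2-fold higher number from compound 3 to compound 4 (0.07 log units; within the scatter) is therefore expected, a number within or barely beyond the scatter. Compound 4 is estimated at 7000 nM, with a range from 3000 nM to 16000 nM.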

Compound 4, half-maximal inhibitory concentration: 5300 nM
For compound 4 the middle estimate is 1.3-fold (0.12 log units) above the measured one; measured number inside the range.
By their numbers in this assay, from the lowest: compounds 4, 3 and 1 (each within the scatter of the next); then compound 2.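

In this assay, hydroxy in place of dimethylamino at this spot gives a 1.1-fold lower number from compound 3 to compound 4 (0.05 log units; within the scatter) even though hydroxy carries a hydrogen-bond donor and dimethylamino carries none, so these two groups cannot be told apart here. Taking the methyl off the oxygen of compound 2 gives a 3.6-fold lower number from compound 2 to compound 4 (0.55 log units; beyond the scatter) and is a real if modest step, which leaves methoxy as the one group that stands apart from hydroxy and dimethylamino at this spot, whereas the change from 3-hydroxyphenyl to 4-hydroxyphenyl gives a 1.3-fold lower number from compound 1 to compound 4 (0.10 log units; within the scatter) and so shows no effect of where the hydroxy sits. No measurement at hand explains why methoxy stands apart.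

From the compounds shown here alone, it remains open whether an amine or a carboxylic acid at this spot would fall with hydroxy and dimethylamino or with methoxy. Going by these compounds, whether a shorter chain on the amide would keep these numbers also remains open.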